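The compounds below may be only part of what the source reports. "The series", "measured", "known", "first", "only" and "open" are said of these compounds alone.

Values in a functional assay on OVCAR-8 cells (Homo sapiens) for antiproliferative activity (on this read-out higher numbers stand for weaker inhibition and lower numbers for stronger inhibition), measured so far

- compound 1 `Cn1ncc(Cl)c1-c1cc(C(=O)N[C@@H]2CN[C@H](CCN3CCC(O)CC3)C[C@H]2c2ccc(Cl)c(Cl)c2)oc1Cl` gives 15900 nM 
- compound 2 `Cn1ncc(Cl)c1-c1cc(C(=O)N[C@@H]2CN[C@H](CC(=O)O)C[C@H]2c2ccc(Cl)c(Cl)c2)oc1Cl` gives 5120 nM 
- compound 3 `CCC[C@@H]1C[C@@H](c2ccc(Cl)c(Cl)c2)[C@H](NC(=O)c2cc(-c3c(Cl)cnn3C)c(Cl)o2)CN1` gives 1620 nM 
- compound 4 `Cn1ncc(Cl)c1-c1cc(C(=O)N[C@@H]2CN[C@H](CC(=O)NCCO)C[C@H]2c2ccc(Cl)c(Cl)c2)oc1Cl` has no value yet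

Compound 3 has the lowest number of the three, and its gaps to the other two lie beyond the scatter. The change to compound 4 is (2-hydroxyethyl)carbamoyl in place of ethyl on a saturated chain carbon bound to a saturated ring carbon and reads as (2-hydroxyethyl)carbamoyl in place of ethyl on a saturated chain carbon bound to a saturated ring carbon.

The closest measured step is a 3.2-fold lower number from compound 2 to compound 3 (0.50 log units; beyond the scatter) and replaces carboxy with ethyl at that same place. Compound 4 restores a carbonyl there, so this modest step, read in reverse, points to a higher number. The larger step of a 9.8-fold lower number from compound 1 to compound 3 (0.99 log units; beyond the scatter) points the same way, and a 3.1-fold lower number from compound 1 to compound 2 (0.49 log units; beyond the scatter) shows that the group at this place can shift the number by a modest amount. For the measured compounds named here, none of the measured compounds carries the amide of compound 4, so the read-across is loose.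

A modest rise is expected, of about the size seen with compound 2. The estimate means an expected 3.1-fold higher number from compound 3 to compound 4 (0.49 log units; beyond the scatter) and no larger. For compound 4 the estimated value is 5000 nM with an expected range of 2000 nM to 14000 nM in this read-out.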

Compound 4, half-maximal inhibitory concentration: 1450 nM
Estimate against measurement, compound 4: 3.4-fold (0.54 log units) above, and the stated range ends above it.
By their numbers in this assay, from the lowest: compounds 4 and 3 (each within the scatter of the next); then compound 2; then compound 1.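

In this assay, the place on a saturated chain carbon bound to a saturated ring carbon accepts (2-hydroxyethyl)carbamoyl, with 6 heavy atoms and 2 hydrogen-bond donors, in place of ethyl, with 2 heavy atoms and no donors, at a 1.1-fold lower number from compound 3 to compound 4 (0.05 log units; within the scatter); the two compounds therefore stand level, and added size at this place does not by itself go with a higher number. A carbonyl at this place does not go with a higher number either: compound 2 also carries one, yet a 3.5-fold lower number from compound 2 to compound 4 (0.55 log units; beyond the scatter) comes from (2-hydroxyethyl)amino in place of hydroxy on that carbonyl carbon, so what is attached to the carbonyl matters. With an 11-fold lower number from compound 1 to compound 4 (1.04 log units; beyond the scatter), the gap from the (4-hydroxypiperidin-1-yl)methyl group is the widest in the set, which leaves compound 1 alone at the high end.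

No measured data bear on why these groups differ. Open, going by these compounds, is how a primary amide or a methyl ester at this place would compare, and whether the hydroxy at the end of the (2-hydroxyethyl)carbamoyl chain contributes anything beyond an ethylamide.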